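A Biaryl Series Trimmed to a Bromophenyl Amide

The source may hold more compounds than are shown below. What is called first, only, known or untested is meant among the compounds shown, and "the series" means these compounds.

Compound 1 `CCOC(=O)CCCCCOc1cccc(CN(C(=O)c2ccc(-c3ccc(C(C)=O)s3)cc2)C(C)C)c1`: in an ADME assay on Raji cells (Homo sapiens) for cytotoxicity, read by CellTiter-Glo and resazurin assay, with a stated time of 72 h (a higher number here means that more compound is needed for the effect, a lower number that less compound is needed), compound 1 gives > 26000 nM, a limit of the assay.
Compound 2 `CCOC(=O)CCCCCOc1cccc(CN(C(=O)c2ccc(-c3cccc(Cl)c3)cc2)C(C)C)c1`: in this assay compound 2 gives > 18400 nM, also a limit of the assay.

Neither measured compound yields a number. Going by the values given here, compound 2 sits at its limit (the limit of > 18400 nM in this assay, at which 1 of the 2 values shown sits), and the only other value shown, that of compound 1, is likewise a limit (the limit of > 26000 nM in this assay, at which 1 of the 2 values shown sits). The change from compound 1 to compound 2, 3-chlorophenyl in place of 5-acetylthiophen-2-yl on an aromatic carbon, gives a step that the two limits leave unreadable from compound 1 to compound 2, so its size cannot be read.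

Compound 3 `CCOC(=O)CCCCCOc1cccc(CN(C(=O)c2ccc(Br)cc2)C(C)C)c1` carries the next change: bromo in place of 3-chlorophenyl on an aromatic carbon. Among the compounds with values here, no measured step addresses this exchange, and the single step that exists is unreadable, so the data give no direction for this assay here. On what is shown, compound 3 is expected to remain at or beyond the limit, and compound 3 is estimated at 30000 nM, within 10000 nM to 100000 nM. The step from compound 2 to compound 3 is therefore expected to be a step that the limit leaves unreadable from compound 2 to compound 3, no change beyond the scatter.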

Compound 3, half-maximal effective concentration: > 26000 nM
Compound 3 gave a limit, no number (the forecaster's own chance of this, stated with the estimate: 85%); the middle value is on the limit's open side.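

In this assay compound 3 gives > 26000 nM, a limit of the assay. With compound 1 and compound 2 also at limits, the steps linking compound 3 to each of them cannot be read. The compounds shown leave open whether bromo, 3-chlorophenyl and 5-acetylthiophen-2-yl differ at all in this assay.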